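A few compounds are considered here, and "the series" means these few. Any claim that something is new, unique, unknown or untested is made for them only; others in the source may bear on it.

Three amides built on one shared core were tested in an assay on LtK cells with ATP-sensitive inward rectifier potassium channel 11 (Homo sapiens) as the target; on this read-out higher numbers stand for an effect only at larger amounts of compound and lower numbers for an effect already at smaller amounts. Compound 1 `CC(C)OC(=O)Nc1c(C(O)(C(F)(F)F)C(F)(F)F)ccc2ccccc12` gives 1160 nM. Compound 2 `COc1ccc(C(=O)Nc2c(C(O)(C(F)(F)F)C(F)(F)F)ccc3ccccc23)cc1` gives 417 nM, and the change a 2.8-fold lower number from compound 1 to compound 2 (0.44 log units; beyond the scatter) is a modest step. Compound 3 `O=C(Nc1c(C(O)(C(F)(F)F)C(F)(F)F)ccc2ccccc12)c1ccc(OC(F)(F)F)cc1` gives only a limit of the assay, > 10000 nM, so no number is known for it. Among the compounds with values here, this is the one value of the three that sits at the limit (the limit of > 10000 nM in this assay, at which 1 of the 3 values shown sits). Against the two measured compounds, the steps of an at least 8.6-fold higher number from compound 1 to compound 3 (0.93 log units; beyond the scatter) and an at least 23-fold higher number from compound 2 to compound 3 (1.37 log units; beyond the scatter) are both beyond the scatter, the second large, so compound 3 stands weakest of the three.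

Compound 4 `O=C(Nc1c(C(O)(C(F)(F)F)C(F)(F)F)ccc2ccccc12)c1cccc(Cl)c1Cl` carries the change (2,3-dichlorophenyl in place of 4-(trifluoromethoxy)phenyl on a carbonyl carbon). Two measured steps bear on it: the aryl amide without a trifluoromethoxy group, compound 2, gave the lowest number shown, and the trifluoromethoxy group in compound 3 pushed the value past the limit. Within the data shown here, removing that group and placing a dichlorophenyl on the carbonyl carbon is expected to bring the number back down, though the two chlorines have no measured precedent here. Compound 4 is therefore expected to give about 1200 nM, within 250 nM to 8000 nM. This expected step of an at least 8.3-fold lower number from compound 3 to compound 4 (0.92 log units; beyond the scatter) is an estimate only.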

Compound 4, half-maximal effective concentration: > 10000 nM
Compound 4: only a limit was reported; the forecaster's own chance of this, stated with the estimate: 25%; middle value at least 8.3-fold (0.92 log units) away from the limit.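

In this assay compound 4 gives > 10000 nM, which is a limit of the assay and not a number. Replacing the 4-methoxyphenyl group gives an at least 23-fold higher number from compound 2 to compound 4 (1.37 log units; beyond the scatter), and replacing the isopropoxy group gives an at least 8.6-fold higher number from compound 1 to compound 4 (0.93 log units; beyond the scatter), so on this carbonyl carbon an aryl group without trifluoromethoxy does not by itself give a readable value, and compound 2 stands against any rule that aryl groups here fail or succeed as a class. The step between compound 3 and compound 4 cannot be read, because both stand at the limit, which now holds a second aryl amide: the limit of > 10000 nM in this assay, at which 2 of the 4 values shown sit.

Going by these compounds, with only compound 2 giving a number among the three aryl amides, it remains open which feature of the 4-methoxyphenyl group separates it from the 4-(trifluoromethoxy)phenyl and 2,3-dichlorophenyl groups. Also open, on these data alone, is how this assay would respond to a plain phenyl group, a phenyl group with a single chlorine, or a phenyl group carrying an amine or a carboxylic acid on this carbonyl carbon.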